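The source may report more compounds than this note shows. Statements on the series, on what has been measured and on what is new or still open speak of the compounds shown alone.

Measured so far:
compound 1 `CC(C)CCn1nc(CCC(F)(F)F)c(O)c(C2=NS(=O)(=O)c3cc(NS(C)(=O)=O)ccc3N2)c1=O` — > 33000 nM
compound 2 `CS(=O)(=O)Nc1ccc2c(c1)S(=O)(=O)N=C(c1c(O)c(-c3cccs3)nn(CC3CCC3)c1=O)N2` — > 1000 nM

In an ADME assay on Huh-7 cells (Homo sapiens) for cytotoxicity, with a stated time of 72 h (a lower number here means that less compound is tolerated, a higher number that more compound is tolerated), compound 1 is known only as a limit, > 33000 nM. Compound 2 is likewise known only as a limit, > 1000 nM. Compound 2 therefore stands at the limit of > 1000 nM in this assay, at which 1 of the 2 values shown sits, and nothing more precise is known of it in this assay.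

Compound 3 `CS(=O)(=O)Nc1ccc2c(c1)S(=O)(=O)N=C(c1c(O)c(-c3cccs3)nn(CCC3CCCC3)c1=O)N2` differs from compound 2 by cyclopentylmethyl in place of cyclobutyl on a saturated chain carbon bound to an aromatic nitrogen. Among the measured compounds shown here, no measured step between two compounds is available, so no size of change can be drawn from the data; the expected step is none beyond the scatter, as a step that the limit leaves unreadable from compound 2 to compound 3. Compound 3 is expected at 3000 nM, within 1000 nM to 30000 nM, and most likely reported again only as a limit.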

Compound 3, half-maximal cytotoxic concentration: > 1000 nM
Compound 3 was reported as a limit (the forecaster's own chance of this, stated with the estimate: 70%); the middle value is on the limit's open side.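

In this assay compound 2 gives > 1000 nM as a limit. Compound 3 gives > 1000 nM as a limit too, so no step can be read between compound 2 and compound 3. Still open, on these data alone, is whether cyclopentylmethyl in place of cyclobutyl shifts the half-maximal cytotoxic concentration at all.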